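Sulfonamide in Place of Amide on a Shared Core

The source may report more compounds than this note shows. Statements on the series, on what has been measured and on what is new or still open speak of the compounds shown alone.

Among the compounds with values here, compound 2 `CNC(=O)c1cccc2c1CCC2c1ncc[nH]1` stands as the higher of the two numbers so far: in a functional assay on CHO cells for agonist activity at Alpha-1A adrenergic receptor (Homo sapiens), read by FLIPR and calcium flux (a lower number here means that less compound is needed, a higher number that more compound is needed for the effect), compound 2 gives 2200 nM, whereas compound 1 `Cc1oncc1-c1cccc2c1CCC2c1ncc[nH]1` gives 111 nM. Within the data shown here, the only measured step, a 20-fold higher number from compound 1 to compound 2 (1.30 log units; beyond the scatter), shows that the substituent at this position matters greatly. Compound 3 `CCS(=O)(=O)Nc1cccc2c1CCC2c1ncc[nH]1` differs from compound 2 by (ethylsulfonyl)amino in place of methylcarbamoyl on an aromatic carbon. Among the measured compounds shown here, no measured step swaps one polar group for another, so the expected step from compound 2 to compound 3 is modest and uncertain, estimated at a 1.1-fold lower number from compound 2 to compound 3 (0.04 log units; within the scatter). Compound 3 is accordingly expected to give about 2000 nM, within 600 nM to 7000 nM.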

Compound 3, half-maximal effective concentration: 32 nM
Estimate against measurement, compound 3: 63-fold (1.80 log units) above; measured number outside the range, below it.
By their numbers in this assay, from the lowest: compound 3; then compound 1; then compound 2.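

In this assay, this position proves able to give a much lower number than the first pair suggested: (ethylsulfonyl)amino gives a 69-fold lower number from compound 2 to compound 3 (1.84 log units; beyond the scatter), and it also outdoes 5-methyl-1,2-oxazol-4-yl, with a 3.5-fold lower number from compound 1 to compound 3 (0.54 log units; beyond the scatter). Methylcarbamoyl and (ethylsulfonyl)amino have the same count of hydrogen-bond donors, so that count alone does not set the number here. No evidence at hand explains these steps.

Still open, going by these compounds, is whether a chain longer than ethyl on the sulfonyl keeps the low number, and whether a methylsulfonyl group without the nitrogen, or a carboxylic acid, would do the same at this position.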